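This account rests on a few compounds, and the source may have more. Where it says the series, first, only, none or still open, it means among the compounds named here.

Compound 1 `CCCCCn1ccnc1-c1cc(OC)c(OC)c(OC)c1` gives 57900 nM
Compound 2 `COc1cc(-c2nccn2-c2ccc3cc[nH]c3c2)cc(OC)c1OC` gives 1700 nM

Among the measured compounds shown here, these two values come from a functional assay on MDA-MB-468 cells (Homo sapiens) for antiproliferative activity, read by MTT assay, with a stated time of 72 h (on this read-out higher numbers stand for weaker inhibition and lower numbers for stronger inhibition), and are the only measurements so far. Compound 1 has the higher number of the two, which means the weaker inhibition, and its gap to compound 2 lies beyond the usual scatter. The next compound to be tested is compound 3 `COc1cc(-c2nccn2-c2ccc(Br)cc2)cc(OC)c1OC`. It replaces the pentyl of compound 1 with 4-bromophenyl on an aromatic nitrogen 4-bromophenyl in place of pentyl on an aromatic nitrogen and leaves the rest of the core unchanged. A fall in the number, beyond the scatter, is expected. That expectation rests on compound 2, which at 1700 nM also carries no pentyl on that nitrogen. The estimated step of a 14-fold lower number from compound 1 to compound 3 (1.16 log units; beyond the scatter) points toward stronger inhibition. Compound 3 is estimated at 4000 nM (expected range 800 nM to 20000 nM).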

Compound 3, half-maximal inhibitory concentration: 2700 nM
For compound 3 the middle estimate is 1.5-fold (0.17 log units) above the measured one; low and high end bracket the measured number.
By their numbers in this assay, from the lowest: compounds 2 and 3 (each within the scatter of the next); then compound 1.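

On the aromatic nitrogen of the shared core, 4-bromophenyl in place of pentyl gives a 21-fold lower number from compound 1 to compound 3 (1.33 log units; beyond the scatter) in this assay, which shows that activity depends strongly on the group at this position. The gain does not depend on the particular ring group of compound 2, since a single six-membered aromatic ring carrying bromine serves as well: compound 2 at 1700 nM and compound 3 at 2700 nM lie within the scatter of each other. No measurement available here bears on why the exchange has this effect.

As far as these compounds go, whether the bromine itself contributes remains open, as does how an unsubstituted phenyl or a 4-methoxyphenyl would compare. Also open, from the compounds shown here alone, is whether an aromatic ring is needed on that nitrogen at all, or whether a benzyl or a shorter chain such as propyl would do.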